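A Second Ring Nitrogen on the Distal Aryl Group

A few compounds are considered here, and "the series" means these few. Any claim that something is new, unique, unknown or untested is made for them only; others in the source may bear on it.

Compound 2 `CN1CCC[C@H]1COc1cncc(-c2cccnc2)c1` carries a pyridin-3-yl group on the shared core, and in an assay on membranes from brain for binding affinity to Neuronal acetylcholine receptor; alpha4/beta2 (Rattus norvegicus) (a higher number here means a weaker inhibitor, a lower number a stronger inhibitor), compound 2 gives 0.27 nM. Among the compounds with values here, this is the lowest of the two numbers recorded, but its only neighbour lies within the scatter: compound 1 `CN1CCC[C@H]1COc1cncc(-c2cccc(N)c2)c1` bears a 3-aminophenyl group at the same position, and in this assay compound 1 gives 0.43 nM. The step of a 1.6-fold lower number from compound 1 to compound 2 (0.20 log units; within the scatter) therefore shows that swapping one aromatic substituent for another at this site left the number essentially unchanged.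

Compound 3 `CN1CCC[C@H]1COc1cncc(-c2cncnc2)c1` differs from compound 2 by pyrimidin-5-yl in place of pyridin-3-yl on an aromatic carbon. Within the data shown here, no measured step changes a pyridin-3-yl into a pyrimidin-5-yl, so the only guide is the indifference of this assay to the earlier aryl swap from compound 1 to compound 2. On that basis the step from compound 2 to compound 3 is expected to stay within the scatter, estimated as a 1.9-fold higher number from compound 2 to compound 3 (0.27 log units; within the scatter). Compound 3 is accordingly estimated at 0.5 nM, with a range from 0.15 nM to 1.8 nM.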

Compound 3, inhibition constant: 0.37 nM
For compound 3 the middle estimate is 1.4-fold (0.13 log units) above the measured one; the range from low to high includes it.
By their numbers in this assay, from the lowest: compounds 2, 3 and 1 (each within the scatter of the next).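

In this assay the second ring nitrogen of pyrimidin-5-yl, set where pyridin-3-yl stood, gives a 1.4-fold higher number from compound 2 to compound 3 (0.14 log units; within the scatter) and so adds a hetero atom to the distal ring without a step beyond the scatter. Within the data shown here, the earlier pair had only compared 3-aminophenyl with pyridin-3-yl, whereas a 1.2-fold lower number from compound 1 to compound 3 (0.07 log units; within the scatter) now extends that comparison to a ring with 2 hetero atoms, leaving all three groups at this position within the scatter of one another, with no compound among them that can be set apart. No measurement at hand bears on why the numbers at this position stay so close together.

All three groups are six-membered aromatic rings, so the compounds shown leave open whether a carboxylic acid, a morpholine or a short alkyl chain on the same aromatic carbon would stay in this range. They also leave open whether a second ring nitrogen placed elsewhere in the distal ring, as in pyrazin-2-yl, would behave as pyrimidin-5-yl does here.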